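Positional isomer in the benzylsulfanyl arm: compound 3 to compound 4

The source may hold more compounds than are shown below. What is called first, only, known or untested is meant among the compounds shown, and "the series" means these compounds.

Measured so far:
compound 1 `C/C(C#Cc1ccccc1)=N\N/C(N)=N/S(=O)(=O)c1cc(C)c(Cl)cc1SCc1ccc(C)cc1`: 110000 nM
compound 2 `C/C(C#Cc1ccccc1)=N\N/C(N)=N/S(=O)(=O)c1cc(C)c(Cl)cc1SCc1ccc(C(F)(F)F)cc1`: 8000 nM
compound 3 `C/C(C#Cc1ccccc1)=N\N/C(N)=N/S(=O)(=O)c1cc(C)c(Cl)cc1SCc1cccc(Cl)c1`: 21000 nM

All three share one core and differ only in the aryl group on the saturated chain carbon bound to a sulfur. In a functional assay on HeLa cells (Homo sapiens) for antiproliferative activity, read by MTT assay, with a stated time of 72 h (a higher number here means a weaker inhibitor, a lower number a stronger inhibitor), compound 3 gives 21000 nM, the second highest of the three numbers; its nearest neighbour is compound 2 at 8000 nM, its furthest compound 1 at 110000 nM. The steps among the measured compounds are a 14-fold lower number from compound 1 to compound 2 (1.14 log units; beyond the scatter), a 5.2-fold lower number from compound 1 to compound 3 (0.72 log units; beyond the scatter) and a 2.6-fold higher number from compound 2 to compound 3 (0.42 log units; beyond the scatter).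

Compound 4 `C/C(C#Cc1ccccc1)=N\N/C(N)=N/S(=O)(=O)c1cc(C)c(Cl)cc1SCc1ccc(Cl)cc1` is the untested member. Its change from compound 3 is 4-chlorophenyl in place of 3-chlorophenyl on a saturated chain carbon bound to a sulfur. Going by the values given here, no measured step swaps a chlorine from one ring position to another, so none bears directly on this move; the only steps seen exchange a methyl for trifluoromethyl or for chlorine, and those were large to modest. With a chlorine kept and only its position shifted, the expectation is a small step, if any, and a number near that of compound 3 is estimated for compound 4: 15000 nM in this assay, with a range of 6000 nM to 40000 nM. This expected step, a 1.4-fold lower number from compound 3 to compound 4 (0.15 log units; within the scatter), would lie within the usual scatter.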

Compound 4, half-maximal inhibitory concentration: 8000 nM
Estimate against measurement, compound 4: 1.9-fold (0.27 log units) above; measured number inside the range.
By their numbers in this assay, from the lowest: compounds 2 and 4 (each within the scatter of the next); then compound 3; then compound 1.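

In this assay, the position of a single chlorine on the aryl group at this saturated chain carbon bound to a sulfur is not neutral: a 2.6-fold lower number from compound 3 to compound 4 (0.42 log units; beyond the scatter). The earlier steps shown here all changed the substituent itself, whereas this pair keeps the same atoms and changes only how they are joined, so the effect of ring position is now separated from the effect of substituent identity. Among the compounds with a 4-substituted phenyl, chloro and trifluoromethyl cannot be told apart, with no change at the digits printed from compound 2 to compound 4 (within the scatter), while methyl stands clearly apart, with a 14-fold lower number from compound 1 to compound 4 (1.14 log units; beyond the scatter); no measurement available here bears on why the number moves with either change.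

Going by these compounds, whether trifluoromethyl responds to a shift in ring position as chlorine does remains open, since these compounds show that shift for chlorine alone. Also open, on these data alone, is where a methoxy group, a nitrile or a carboxylic acid on the same ring would fall relative to the chloro and methyl compounds, and whether these steps would carry over to cell lines other than HeLa.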